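Dienone series: nitro to methyl on the aryl ring

The source may report more compounds than this note shows. Statements on the series, on what has been measured and on what is new or still open speak of the compounds shown alone.

Measured compounds:
compound 1 `CC1=C(/C=C/C(=O)/C=C/c2cccc([N+](=O)[O-])c2)C(C)(C)CCC1` — 10000 nM
compound 2 `CC1=C(/C=C/C(=O)/C=C/c2cccc(C)c2)C(C)(C)CCC1` — 35000 nM
compound 3 `CC1=CCCC(C)(C)C1/C=C/C(=O)/C=C/c1cccc([N+](=O)[O-])c1` — 2900 nM

All three values come from a functional assay on PC-3 cells (Homo sapiens) for cytotoxicity, read by MTT assay, with a stated time of 72 h; on this read-out lower numbers stand for stronger inhibition and higher numbers for weaker inhibition. Compound 1 and compound 2 share one core; compound 3 has a core of the same atoms joined differently, and the difference between the two cores is not broken down here. Compound 3 gives the lowest number of the three.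

Within the first core, the change methyl in place of nitro on an aromatic carbon gave a 3.5-fold higher number from compound 1 to compound 2 (0.54 log units; beyond the scatter). Compound 4 `CC1=CCCC(C)(C)C1/C=C/C(=O)/C=C/c1cccc(C)c1` is not yet measured in this assay; it carries the same change on the core of compound 3, (methyl in place of nitro on an aromatic carbon), at the same place.

Among the compounds with values here, with only one earlier instance to rest on, the step from compound 3 to compound 4 is expected to be of similar size, a 3.4-fold higher number from compound 3 to compound 4 (0.54 log units; beyond the scatter), because a 3.5-fold higher number from compound 1 to compound 2 (0.54 log units; beyond the scatter) is the only precedent. Compound 4 is therefore estimated at 10000 nM, with a likely range from 4000 nM to 25000 nM.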

Compound 4, half-maximal inhibitory concentration: 5900 nM
Beside the measured number, compound 4's estimate is 1.7-fold (0.23 log units) above it; low and high end bracket the measured number.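

In this assay, methyl in place of nitro on an aromatic carbon also raises the number on the second core, giving a 2.0-fold higher number from compound 3 to compound 4 (0.31 log units; beyond the scatter). The step runs in the same direction on both cores, and its two sizes cannot be told apart: the same change on two cores in this assay, a 3.5-fold higher number (0.54 log units; beyond the scatter) from compound 1 to compound 2 and a 2.0-fold higher number (0.31 log units; beyond the scatter) from compound 3 to compound 4, 1.7-fold (0.24 log units) apart, within the scatter of two such steps. Within the data shown here, this supports carrying the change between these two cores, but it rests on only two pairs at one place on the ring and says nothing about any other core.

Going by these compounds, it remains open whether other groups at this place, such as an amine or a carboxylic acid, would also carry across the two cores. On these data alone, it also remains open whether the step from nitro to methyl holds elsewhere on the aromatic ring.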